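The compounds below may be only part of what the source reports. "The series", "measured", "known", "first", "only" and "open" are said of these compounds alone.

In an assay on isolated protein for binding affinity to Equilibrative nucleoside transporter 1 (Homo sapiens) (on this read-out lower numbers stand for stronger inhibition and higher numbers for weaker inhibition), compound 3 `O=[N+]([O-])c1ccc(CNc2ncnc3c2ncn3[C@@H]2O[C@H](CO)[C@@H](O)[C@H]2O)c(Cl)c1` gives 347 nM, the lowest of the three numbers measured, though compound 2 `Cc1c(CNc2ncnc3c2ncn3[C@@H]2O[C@H](CO)[C@@H](O)[C@H]2O)cccc1[N+](=O)[O-]`, with 427 nM, sits within the scatter of it. Compound 1 `CCCCCNc1ncnc2c1ncn2[C@@H]1O[C@H](CO)[C@@H](O)[C@H]1O` gives 13500 nM in this assay. Among the measured compounds shown here, the large steps of a 32-fold lower number from compound 1 to compound 2 (1.50 log units; beyond the scatter) and a 39-fold lower number from compound 1 to compound 3 (1.59 log units; beyond the scatter) came from replacing butyl with a nitro-substituted aryl ring, while the step of a 1.2-fold lower number from compound 2 to compound 3 (0.09 log units; within the scatter), the one exchange of one such aryl ring for another, lay within the scatter. Compound 4 `Cc1ccc([N+](=O)[O-])c(CNc2ncnc3c2ncn3[C@@H]2O[C@H](CO)[C@@H](O)[C@H]2O)c1` arises from compound 3 by 5-methyl-2-nitrophenyl in place of 2-chloro-4-nitrophenyl on a saturated chain carbon bound to a nitrogen on an aromatic ring. This is again an exchange of one nitro-substituted aryl ring for another, so no step beyond the scatter is expected in this assay. Compound 4 is therefore estimated at 400 nM, with a range from 150 nM to 1100 nM. The expected step is a 1.2-fold higher number from compound 3 to compound 4 (0.06 log units; within the scatter).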

Compound 4, half-maximal inhibitory concentration: 1290 nM
Beside the measured number, compound 4's estimate is 3.2-fold (0.51 log units) below it, and the stated range ends below it.
By their numbers in this assay, from the lowest: compounds 3 and 2 (each within the scatter of the next); then compound 4; then compound 1.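

Exchanging one nitro-substituted aryl ring for another at this position can move the number in this assay beyond the scatter: 5-methyl-2-nitrophenyl gives a 3.7-fold higher number from compound 3 to compound 4 (0.57 log units; beyond the scatter) and a 3.0-fold higher number from compound 2 to compound 4 (0.48 log units; beyond the scatter) whereas the earlier exchange of such rings did not. This ring still keeps a large gain over butyl, with a 10-fold lower number from compound 1 to compound 4 (1.02 log units; beyond the scatter) in the same read-out. No measurement at hand bears on why these rings differ.

As far as these compounds go, compounds 3 and 4 differ in both ring substituents at once, and which of them carries the step stays open. Equally open, from the compounds shown here alone, is how a phenyl ring bearing an amine or a carboxylic acid instead of the nitro group would stand.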